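The source may hold more compounds than are shown below. What is called first, only, known or untested is meant among the compounds shown, and "the series" means these compounds.

Of the compounds shown here, three sharing one core have been tested in a functional assay on the whole organism for inhibition, with Canis familiaris (Canis lupus familiaris) as the target; on this read-out higher numbers stand for an effect only at larger amounts of compound and lower numbers for an effect already at smaller amounts. Compound 1, `CCN1CCCC1CNC(=O)c1cc(NS(=O)(=O)N(C)C)c(C)cc1OC`, gives 0.05 mg/kg in this assay. Compound 2, `CCN1CCCC1CNC(=O)c1cc(NS(C)(=O)=O)c(C)cc1OC`, gives 1 mg/kg in this assay. Compound 3, `CCN1CCCC1CNC(=O)c1cc(NS(=O)(=O)NC)ccc1OC`, gives in this assay only a limit of the measurement, > 1 mg/kg. Compound 3 thus stands at the limit of > 1 mg/kg in this assay, at which 1 of the 3 values shown sits, with no number attached. Between compound 1 and compound 2 the single change, a 20-fold higher number from compound 1 to compound 2 (1.30 log units; beyond the scatter), is a large step.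

Compound 4, `CCN1CCCC1CNC(=O)c1cc(NS(=O)(=O)NC)c(C)cc1OC`, differs from compound 3 by methyl in place of hydrogen on an aromatic carbon. Among the compounds with values here, no measured pair isolates this change: the only measured step, from compound 1 to compound 2, changes the sulfonyl substituent, and compound 2 and compound 3 differ in two places at once. The ring methyl is carried by both compound 1 and compound 2, which sit at the lower end of the numbers shown, so for compound 4 a number rather than a limit is expected. The step from compound 3 to compound 4 is expected to be an at least 3.3-fold lower number from compound 3 to compound 4 (0.52 log units; beyond the scatter), downward in this assay. Compound 4 is estimated at 0.3 mg/kg in this assay, within a range from 0.05 mg/kg to 2 mg/kg.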

Compound 4, dose for half-maximal effect: > 1 mg/kg
Compound 4 gave a limit, no number (the forecaster's own chance of this, stated with the estimate: 25%); at least 3.3-fold (0.52 log units) between middle value and limit.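

In this assay compound 4 gives no number, only a limit, and it shares that place with compound 3: the limit of > 1 mg/kg in this assay, at which 2 of the 4 values shown sit. With a methylamino group on the sulfonyl sulfur, methyl in place of hydrogen on this aromatic carbon does not bring the read-out to a number, and this step cannot be read. Within the data shown here, the single change of methylamino in place of methyl on a sulfonyl sulfur gives a number no lower from compound 2 to compound 4 (the limit leaves the size open). Among these compounds, the ring methyl is therefore not enough by itself, since compound 1 carries it too and the single change of hydrogen in place of methyl on a sulfonamide nitrogen gives an at least 20-fold higher number from compound 1 to compound 4 (1.30 log units; beyond the scatter).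

Going by these compounds, how far compound 3 and compound 4 lie beyond the limit stays unknown, so it remains open whether the ring methyl changes anything at all when the sulfonyl sulfur carries methylamino. Also open, on these data alone, is how a chlorine atom or an ethyl group would behave on the same aromatic carbon, and whether an ethylamino group on the sulfonyl sulfur would behave like dimethylamino or like methylamino.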